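Swapping bromo for pentyl on a triazole-linked phenyl

A few compounds are considered here, and "the series" means these few. Any claim that something is new, unique, unknown or untested is made for them only; others in the source may bear on it.

Three compounds share one core and differ only in the group on the triazole. Compound 1 `O=c1cc(Cn2cc(C3CC3)nn2)c2ccc(O)cc2o1` carries a cyclopropyl there, and in a functional assay on CFPAC-1 cells (Homo sapiens) for inhibition, read by MTT assay, with a stated time of 72 h (on this read-out higher numbers stand for weaker inhibition and lower numbers for stronger inhibition), compound 1 gives > 100000 nM, which is a limit of the assay rather than a number. Compound 2 `O=c1cc(Cn2cc(CCCO)nn2)c2ccc(O)cc2o1` carries a 3-hydroxypropyl, and in this assay compound 2 gives > 100000 nM, again a limit. Going by the values given here, compound 3 `O=c1cc(Cn2cc(-c3ccc(Br)cc3)nn2)c2ccc(O)cc2o1` carries a 4-bromophenyl and is the only one with a number: in this assay compound 3 gives 52900 nM. Because two of the three values sit at the limit of > 100000 nM in this assay, at which 2 of the 3 values shown sit, the steps are floors only: an at least 1.8-fold lower number from compound 1 to compound 3 (0.27 log units; that floor lies within the scatter) and an at least 1.8-fold lower number from compound 2 to compound 3 (0.27 log units; that floor lies within the scatter), while a step that the two limits leave unreadable from compound 1 to compound 2. Compound 4 `CCCCCc1ccc(-c2cn(Cc3cc(=O)oc4cc(O)ccc34)nn2)cc1` is not yet measured; it differs from compound 3 by pentyl in place of bromo on an aromatic carbon. Among the compounds with values here, no measured step swaps one group for another on that phenyl, so the measured steps give no direction for this change. The expected step from compound 3 to compound 4 is a 1.3-fold lower number from compound 3 to compound 4 (0.12 log units; within the scatter), within the scatter. Compound 4 is therefore expected to give 40000 nM in this assay, with a range from 12000 nM to 100000 nM.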

Compound 4, half-maximal inhibitory concentration: 50400 nM
Beside the measured number, compound 4's estimate is 1.3-fold (0.10 log units) below it, and the stated range covers the measured number.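

In this assay, the one step shown that changes a group on the phenyl itself gives a 1.0-fold lower number from compound 3 to compound 4 (0.02 log units; within the scatter). Going by these compounds alone, on this aromatic carbon, para to a large group, bromo with 1 heavy atom and pentyl with 5 heavy atoms therefore cannot be told apart, something the earlier compounds could not show, since they changed the whole group on the triazole. Compound 3 and compound 4 both give a readable number in this assay, which compound 1 and compound 2 do not: the limit of > 100000 nM in this assay, at which 2 of the 4 values shown sit.

From the compounds shown here alone, it remains open whether an amine or a carboxylic acid in this place on the phenyl would shift the number beyond the scatter. Going by these compounds, a chain longer than pentyl is equally open, so the tolerance seen here rests on this one pair.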